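This account rests on a few compounds, and the source may have more. Where it says the series, first, only, none or still open, it means among the compounds named here.

The measured compounds and their values:
compound 1, `CSc1ccc(/C=C(\C(=O)c2ccc(Cl)cc2)S(=O)(=O)Cc2ccc(C)cc2)cc1`: 10000 nM
compound 2, `Cc1ccc(CS(=O)(=O)/C(=C/c2c(O)cc(O)cc2O)C(=O)c2ccc(Cl)cc2)cc1`: > 100000 nM
compound 3, `Cc1ccc(CS(=O)(=O)/C(=C/c2cc(C)ccc2C)C(=O)c2ccc(Cl)cc2)cc1`: 1000 nM

In a functional assay on DU-145 cells (Homo sapiens) for inhibition, read by trypan blue exclusion, with a stated time of 96 h (a higher number here means a weaker inhibitor of growth, a lower number a stronger inhibitor of growth), compound 3 gives 1000 nM, the lowest of the two numbers available, its nearest neighbour being compound 1 at 10000 nM, a step told as a 10-fold lower number from compound 1 to compound 3 (1.00 log units; beyond the scatter). For compound 2 the result in this assay is only a limit, > 100000 nM, as recorded in the limit of > 100000 nM in this assay, at which 1 of the 3 values shown sits. Compound 4, `COc1ccccc1/C=C(\C(=O)c1ccc(Cl)cc1)S(=O)(=O)Cc1ccc(C)cc1`, has not yet been measured in this assay. It differs from compound 3 in one place: 2-methoxyphenyl in place of 2,5-dimethylphenyl on a double-bonded chain carbon bound to a double-bonded chain carbon.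

Among the measured compounds shown here, two measured steps bear on this change, both of them exchanges of the aryl group on the double-bonded chain carbon: a 10-fold lower number from compound 1 to compound 3 (1.00 log units; beyond the scatter), a modest step, and an at least 100-fold lower number from compound 2 to compound 3 (2.00 log units; beyond the scatter), a large one. Both steps ran toward compound 3, so a further exchange away from 2,5-dimethylphenyl is expected to move the number upward rather than downward. For the measured compounds named here, with no direct precedent for 2-methoxyphenyl among the measured compounds, the expected step for a 3.0-fold higher number from compound 3 to compound 4 (0.48 log units; beyond the scatter) is modest, and compound 4 is estimated to give 3000 nM in this assay, within a range from 1000 nM to 30000 nM.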

Compound 4, concentration for 50% growth inhibition: 10000 nM
For compound 4 the middle estimate is 3.3-fold (0.52 log units) below the measured one, within the range that was stated.
By their numbers in this assay, from the lowest: compound 3; then compounds 1 and 4 (each within the scatter of the next). At a limit, above all of these: compound 2.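

In this assay, the exchange of 2,5-dimethylphenyl for 2-methoxyphenyl on the double-bonded chain carbon gives a 10-fold higher number from compound 3 to compound 4 (1.00 log units; beyond the scatter), so this position is sensitive even to a swap between two groups of equal heavy-atom count. The exchange of 4-(methylsulfanyl)phenyl for 2-methoxyphenyl gives no change at the digits printed from compound 1 to compound 4 (within the scatter), which leaves compound 3 alone at the low end and makes 2,5-dimethylphenyl, the only one of the four aryl groups built from carbon alone, the best group shown here. The 2-methoxyphenyl group also stands clear of 2,4,6-trihydroxyphenyl, with an at least 10-fold lower number from compound 2 to compound 4 (1.00 log units; beyond the scatter), though that step rests on a limit and not on a number: the limit of > 100000 nM in this assay, at which 1 of the 4 values shown sits.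

As far as these compounds go, what stays open is whether the lower number of compound 3 follows both methyl groups together or only one of them, a question that a 2-methylphenyl or a 3-methylphenyl group at this place would settle. From the compounds shown here alone, it also remains open whether a 2,5-dimethoxyphenyl group would behave like compound 3 or like compound 4, and how an amine or a carboxylic acid on this aryl ring would fare.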